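Series notes: carbamate chain in place of methoxy

The compounds below may be only part of what the source reports. "The series", "measured", "known", "first", "only" and "open" are said of these compounds alone.

Measured compounds in an assay on MCF7 cells for inhibition of Serine-protein kinase ATM (Homo sapiens), read by immunofluorescence, with a stated time of 1 h; on this read-out lower numbers stand for stronger inhibition and higher numbers for weaker inhibition:
- compound 1, `Nc1cc2c(-n3nc(-c4ccccn4)nc3N)ncnc2cc1Cl`: > 40000 nM
- compound 2, `COCCOc1cc2ncnc(-n3nc(-c4ccccn4)nc3N)c2cc1OCCOC`: 2300 nM
- compound 3, `COCCOc1cc2c(-n3nc(-c4ccccn4)nc3N)ncnc2cc1OC`: 1200 nM

The value of compound 1 is a limit of this assay, not a number (the limit of > 40000 nM in this assay, at which 1 of the 3 values shown sits). Compound 3 has the lowest of the two numbers shown, but its nearest neighbour is compound 2, and the step of a 1.9-fold lower number from compound 2 to compound 3 (0.28 log units; within the scatter) lies within the scatter, so no order between these two can be claimed.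

Compound 4, `COc1cc2ncnc(-n3nc(-c4ccccn4)nc3N)c2cc1OCCCNC(=O)OC(C)C`, has not been measured in this assay. It differs from compound 3 in one place: ((isopropoxycarbonyl)amino)methyl in place of methoxy on a saturated chain carbon, two bonds along the chain from an oxygen on an aromatic ring. Among the measured compounds shown here, no measured step bears on this particular change; the only measured step, a 1.9-fold lower number from compound 2 to compound 3 (0.28 log units; within the scatter), concerns a different position along the same chain and was within the scatter. For compound 4 the step of a 1.2-fold lower number from compound 3 to compound 4 (0.08 log units; within the scatter) is therefore expected to be small, with no direction established beyond the scatter. Compound 4 is expected to give about 1000 nM in this assay, in a range from 300 nM to 4000 nM.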

Compound 4, half-maximal inhibitory concentration: 1000 nM
Beside the measured number, compound 4's estimate shows no gap at the digits printed, and the stated range covers the measured number.
By their numbers in this assay, from the lowest: compounds 4, 3 and 2 (each within the scatter of the next, the first and the last beyond it). At a limit, above all of these: compound 1.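

In this assay, ((isopropoxycarbonyl)amino)methyl in place of methoxy on a saturated chain carbon, two bonds along the chain from an oxygen on an aromatic ring, gives a 1.2-fold lower number from compound 3 to compound 4 (0.08 log units; within the scatter), so this much larger group leaves the number within the scatter. Until now this chain was seen only as 2-methoxyethoxy; compound 4 shows that 3-((isopropoxycarbonyl)amino)propoxy, which also enters with a hydrogen-bond donor, is compatible with a number of the same size. No measurement shown gives a reason for this result.

On these data alone, whether a primary amine or a carboxylic acid in place of the carbamate, or a longer chain, would move the number beyond the scatter stays open. Also open, as far as these compounds go, is whether the same carbamate chain behaves alike on the other oxygen of the shared core.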